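The compounds below may be only part of what the source reports. "The series", "measured", "known", "first", "only" and "open" are said of these compounds alone.

Compound 2 `O=C(NCc1ccc(S(=O)(=O)c2ccccc2)cc1)c1ccc2nncn2c1` was examined in a functional assay on A2780 cells (Homo sapiens) for inhibition, read by sulforhodamine B assay, with a stated time of 72 h; on this read-out lower numbers stand for stronger inhibition and higher numbers for weaker inhibition. In this assay compound 2 gives > 10000 nM, which is a limit of the assay and not a number. For the measured compounds named here, its only measured neighbour is compound 1 `O=C(NCc1ccc(S(=O)(=O)c2ccccc2)cc1)c1cc2ncccc2s1`, which differs in one group on the carbonyl carbon. In this assay compound 1 gives > 10000 nM, again a limit. The step that the two limits leave unreadable from compound 1 to compound 2 cannot be sized because of the limit of > 10000 nM in this assay, at which 2 of the 2 values shown sit. Compound 3 `O=C(NCc1ccc(S(=O)(=O)c2ccccc2)cc1)c1cnc2nccn2c1` carries the change (a group of 9 heavy atoms (6 carbon, 3 nitrogen; one five-membered aromatic ring with 2 hetero atoms, one six-membered aromatic ring with 2 hetero atoms) in place of a group of 9 heavy atoms (6 carbon, 3 nitrogen; one five-membered aromatic ring with 3 hetero atoms, one six-membered aromatic ring with 1 hetero atom), on a carbonyl carbon). No measured step bears on a rearrangement of this kind, and neither shown value offers a number below the limit to start from, so no step beyond the scatter can be expected in this assay in either direction, and a limit seems the likeliest outcome once more. The expected step is a step that the limit leaves unreadable from compound 2 to compound 3. For compound 3 the estimate in this assay is 15000 nM, expected to lie between 4000 nM and 60000 nM.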

Compound 3, half-maximal inhibitory concentration: 68 nM
For compound 3 the middle estimate is 220-fold (2.34 log units) above the measured one, and the stated range ends above it.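

The group on the carbonyl carbon proves decisive in this assay, with an at least 140-fold lower number from compound 2 to compound 3 (2.16 log units; beyond the scatter) and an at least 140-fold lower number from compound 1 to compound 3 (2.16 log units; beyond the scatter). In the first of these steps the atoms and the counted hydrogen-bond acceptors stay the same and only their joining differs, so the way the hetero atoms are shared between the five-membered and six-membered aromatic rings matters, not the atom count alone. Both steps are minimum sizes, and the step between compound 1 and compound 2 cannot be read because both compounds sit at a limit: the limit of > 10000 nM in this assay, at which 2 of the 3 values shown sit.

The compounds shown do not tell which nitrogen of the group in compound 3 matters, or why this rearrangement has so large an effect. On these data alone, whether a methyl or an amine added to this group would keep the value of compound 3 at 68 nM also remains open.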